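This account rests on a few compounds, and the source may have more. Where it says the series, first, only, none or still open, it means among the compounds named here.

Compound 1 `O=C(Nc1nc(-c2ccccc2)nc2c1nnn2Cc1ccccc1)c1ccoc1` gives 10 nM in an assay (strain Wistar) for displacement of a labelled ligand from adenosine receptor A1 (Rattus norvegicus), read by scintillation counting; a higher number here means a weaker inhibitor, a lower number a stronger inhibitor. Compound 2 `Nc1nc(-c2ccccc2)nc2c1nnn2Cc1ccccc1` gives 5.6 nM. Compound 3 `O=C(Nc1nc(-c2ccccc2)nc2c1nnn2Cc1ccccc1)C1CCCC1` gives 2.5 nM.

Compound 1 stands at the highest of the three numbers; compound 2 sits within the scatter of it, while the gap to the lowest number is a 4.0-fold lower number from compound 1 to compound 3 (0.60 log units; beyond the scatter). Compound 4 `Nc1ccc(C(=O)Nc2nc(-c3ccccc3)nc3c2nnn3Cc2ccccc2)cc1` differs from compound 1 in one place: 4-aminophenyl in place of furan-3-yl on a carbonyl carbon. The step that bears most directly on this change, being made on the same carbonyl carbon, is a 4.0-fold lower number from compound 1 to compound 3 (0.60 log units; beyond the scatter), a modest one; stripping the whole group away, a 1.8-fold lower number from compound 1 to compound 2 (0.25 log units; within the scatter), stayed within the scatter. The amide position thus appears to tolerate change without large movement. Compound 4 is therefore expected to land near compound 1 or somewhat lower, an estimated step of a 1.4-fold lower number from compound 1 to compound 4 (0.15 log units; within the scatter). The estimate for compound 4 is 7 nM, ranging from 2 nM to 25 nM.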

Compound 4, inhibition constant: 7.1 nM
The estimate for compound 4 lay 1.0-fold (0.01 log units) below the measured number; low and high end bracket the measured number.
By their numbers in this assay, from the lowest: compound 3; then compounds 2, 4 and 1 (each within the scatter of the next).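

In this assay, 4-aminophenyl on the carbonyl carbon adds a hydrogen-bond donor and replaces the five-membered aromatic ring with a six-membered one, yet the result is a 1.4-fold lower number from compound 1 to compound 4 (0.15 log units; within the scatter). The full (4-aminophenyl)carbonyl group also stays close to the unsubstituted nitrogen, with a 1.3-fold higher number from compound 2 to compound 4 (0.10 log units; within the scatter). Cyclopentyl remains apart from this aromatic group, at a 2.8-fold higher number from compound 3 to compound 4 (0.45 log units; beyond the scatter), as it does from furan-3-yl. On these data alone, whether a carboxylic acid in place of the amine, or a longer chain on the carbonyl carbon, would shift the number remains open. Nothing measured here explains these differences.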